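Para substitution on the sulfonyl aryl ring

A few compounds are considered here, and "the series" means these few. Any claim that something is new, unique, unknown or untested is made for them only; others in the source may bear on it.

Compound 1 `COc1ccc(CN(c2cc(OC)c(OC)c(OC)c2)S(=O)(=O)c2ccccc2)cc1` gives only a limit in a functional assay on MGC-803 cells (Homo sapiens) for inhibition, read by MTT assay, with a stated time of 48 h (on this read-out lower numbers stand for stronger inhibition and higher numbers for weaker inhibition), > 50000 nM.
Compound 2 `COc1cc(N(Cc2nc3ccccc3[nH]2)S(=O)(=O)c2ccc(C)cc2)cc(OC)c1OC` gives 1020 nM in this assay.
Compound 3 `COc1cc(N(Cc2nc3ccccc3[nH]2)S(=O)(=O)c2ccccc2)cc(OC)c1OC` gives 12400 nM in this assay.

Compound 3 stands highest of the two numbers shown in this assay; its nearest neighbour is compound 2, with a 12-fold higher number from compound 2 to compound 3 (1.08 log units; beyond the scatter). The other step that reaches compound 3 is an at least 4.0-fold lower number from compound 1 to compound 3 (0.60 log units; beyond the scatter), which rests on a limit and tells only that the benzimidazolyl arm improves on the methoxybenzyl arm.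

Compound 4 `COc1cc(N(Cc2nc3ccccc3[nH]2)S(=O)(=O)c2ccc(F)cc2)cc(OC)c1OC` differs from compound 3 by fluoro in place of hydrogen on an aromatic carbon. Within the data shown here, the only measured step at that position is the methyl step, a 12-fold higher number from compound 2 to compound 3 (1.08 log units; beyond the scatter), which was large. Fluoro is a different group, and no step for it is on record, so its size cannot be read directly from the methyl step; a change in the same direction, smaller than the methyl step, is the working expectation. Compound 4 is therefore expected to give about 4000 nM in this assay, within 1500 nM to 12000 nM, a step of a 3.1-fold lower number from compound 3 to compound 4 (0.49 log units; beyond the scatter).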

Compound 4, half-maximal inhibitory concentration: 5680 nM
Beside the measured number, compound 4's estimate is 1.4-fold (0.15 log units) below it; the measured number falls inside the stated range.
By their numbers in this assay, from the lowest: compound 2; then compound 4; then compound 3. At a limit, above all of these: compound 1.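

In this assay, the change from phenyl to 4-fluorophenyl gives a 2.2-fold lower number from compound 3 to compound 4 (0.34 log units; beyond the scatter), so the gain at this position is not confined to methyl: two different groups on this aromatic carbon, para to a large group, now both give lower numbers than the hydrogen of compound 3. The groups also separate from each other, since fluoro in place of methyl gives a 5.6-fold higher number from compound 2 to compound 4 (0.75 log units; beyond the scatter), which leaves methyl as the better of the two and shows that the size of the gain depends on the group entering. Nothing at hand bears on why fluoro and methyl differ here.

Going by these compounds, how chloro, methoxy, trifluoromethyl or an amine at this position would rank against methyl and fluoro stays open. Also open, on these data alone, is whether 4-fluorophenyl or 4-methylphenyl would bring any gain with the 4-methoxyphenyl arm of compound 1, which so far has only a limit.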